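Swapping a Hydroxy for Chloro on a Salicylaldimine

The compounds below may be only part of what the source reports. "The series", "measured", "known", "first", "only" and "open" are said of these compounds alone.

Compound 1 `Cc1cccc(/C=N/c2ccc(OCc3ccccc3)cc2)c1O`: 15500 nM
Compound 2 `Oc1ccc(O)c(/C=N/c2ccc(OCc3ccccc3)cc2)c1`: 1230 nM
Compound 3 `COc1ccc(O)c(/C=N/c2ccc(OCc3ccccc3)cc2)c1`: 10700 nM

In an assay on isolated protein for inhibition of Amine oxidase [flavin-containing] B (Homo sapiens), read by fluorescence and Amplex Red, with stated times of 15 min and 20 min (a higher number here means a weaker inhibitor, a lower number a stronger inhibitor), compound 2 gives the lowest number of the three, and both of its neighbours lie beyond the usual scatter. The step of a 13-fold lower number from compound 1 to compound 2 (1.10 log units; beyond the scatter) and the step of an 8.7-fold higher number from compound 2 to compound 3 (0.94 log units; beyond the scatter) show that the free hydroxy group of compound 2 is tied to its stronger result: capping it as a methoxy in compound 3, or having a different pattern of groups in compound 1, both give a clearly weaker inhibitor.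

Compound 4 `Oc1ccc(Cl)cc1/C=N/c1ccc(OCc2ccccc2)cc1` differs from compound 2 in one place: chloro in place of hydroxy on an aromatic carbon. The chloro group brings no hydrogen-bond donor or acceptor, so the change resembles the methoxy capping seen in the step of an 8.7-fold higher number from compound 2 to compound 3 (0.94 log units; beyond the scatter), where the donor was also lost. A weaker result is therefore expected for compound 4, with a step about as large as that one.

The estimate for compound 4 in this assay is 8000 nM, with a range from 2500 nM to 25000 nM, meaning an expected step of a 6.5-fold higher number from compound 2 to compound 4 (0.81 log units; beyond the scatter).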

Compound 4, half-maximal inhibitory concentration: 24800 nM
The estimate for compound 4 lay 3.1-fold (0.49 log units) below the measured number; the measured number falls inside the stated range.
By their numbers in this assay, from the lowest: compound 2; then compounds 3, 1 and 4 (each within the scatter of the next, the first and the last beyond it).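

At this position, para to a hydroxy group, chloro and methoxy are not interchangeable replacements for hydroxy: the change to chloro gives a large step (a 20-fold higher number from compound 2 to compound 4 (1.30 log units; beyond the scatter)), and chloro in place of methoxy gives a further modest one (a 2.3-fold higher number from compound 3 to compound 4 (0.37 log units; beyond the scatter)). Losing the free hydroxy therefore does not settle the result alone, as the group that replaces it also matters. The chloro compound also stands level with a compound carrying a different ring pattern (a 1.6-fold higher number from compound 1 to compound 4 (0.20 log units; within the scatter)), so both of these changes leave the number in the same range.

The compounds shown leave open whether an amine or a carboxylic acid at this position would keep the lower number of compound 2. No measurement shown here explains why these replacements differ.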